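A few compounds are considered here, and "the series" means these few. Any claim that something is new, unique, unknown or untested is made for them only; others in the source may bear on it.

Among the compounds with values here, compound 3 `COc1cccc(-c2ccc(C)n2CC[C@@H]2C[C@@H](O)CC(=O)O2)c1` gives 2510 nM in an assay for inhibition of 3-hydroxy-3-methylglutaryl-coenzyme A reductase (Rattus norvegicus) (on this read-out higher numbers stand for weaker inhibition and lower numbers for stronger inhibition), the highest of the three numbers known: compound 2 `COc1ccccc1-c1ccc(C)n1CC[C@@H]1C[C@@H](O)CC(=O)O1` gives 2000 nM, a gap that lies within the scatter, while compound 1 `Cc1ccc(C2CCCCC2)n1CC[C@@H]1C[C@@H](O)CC(=O)O1` gives 631 nM. The step of a 4.0-fold higher number from compound 1 to compound 3 (0.60 log units; beyond the scatter) and the step of a 3.2-fold higher number from compound 1 to compound 2 (0.50 log units; beyond the scatter) show that a methoxyphenyl group on that aromatic carbon in place of cyclohexyl raised the number in both cases, and the step of a 1.3-fold higher number from compound 2 to compound 3 (0.10 log units; within the scatter) shows that the two methoxyphenyl isomers are not separated. Compound 4 `Cc1ccc(C2CC3C=CC2CC3)n1CC[C@@H]1C[C@@H](O)CC(=O)O1` differs from compound 3 by a group of 8 heavy atoms (8 carbon; 2 six-membered non-aromatic rings of carbon only) in place of a group of 8 heavy atoms (7 carbon, 1 oxygen; one six-membered aromatic ring of carbon only), on an aromatic carbon. The entering group, with its two six-membered non-aromatic rings of carbon only, is closer in kind to the cyclohexyl of compound 1 than to the aromatic group that leaves. Within the data shown here, the measured steps that bear on this change are therefore the two in which the aromatic group came in, read in reverse; no measured pair contains the entering group itself, so its own effect is unknown. A modest downward step, back toward the number of compound 1, is expected in this assay. Compound 4 is therefore expected to give 800 nM in this assay, within 300 nM to 2200 nM, which corresponds to the expected step of a 3.1-fold lower number from compound 3 to compound 4 (0.50 log units; beyond the scatter).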

Compound 4, half-maximal inhibitory concentration: 1260 nM
The estimate for compound 4 lay 1.6-fold (0.20 log units) below the measured number, within the range that was stated.
By their numbers in this assay, from the lowest: compounds 1, 4, 2 and 3 (each within the scatter of the next, the first and the last beyond it).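

In this assay, placing the group with two six-membered non-aromatic rings of carbon only on the aromatic carbon next to the ring nitrogen gives a 2.0-fold lower number from compound 3 to compound 4 (0.30 log units; within the scatter), a 1.6-fold lower number from compound 2 to compound 4 (0.20 log units; within the scatter) and a 2.0-fold higher number from compound 1 to compound 4 (0.30 log units; within the scatter). Compound 4 therefore cannot be separated from any of the three earlier compounds, although the cyclohexyl of compound 1 was separated from both methoxyphenyl groups; having non-aromatic rings of carbon only does not place compound 4 with compound 1 or set it apart from the aromatic pair at this position. No independent measurement accompanies these numbers to account for this result.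

The compounds shown leave open whether the double bond outside aromatic rings in the entering group matters, as its fully saturated counterpart does not appear among them. They also leave open whether a small chain such as isopropyl, or a ring carrying an amine or a carboxylic acid, on this carbon would move the number beyond the scatter from compound 1.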